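Swapping a Sulfanylphenyl Arm for a Fluoropyridyl Arm

The source may report more compounds than this note shows. Statements on the series, on what has been measured and on what is new or still open speak of the compounds shown alone.

Measured so far:
compound 1, `CSc1ccccc1N1CCN(CCCCn2ncc(=O)n(C)c2=O)CC1` — in an assay for displacement of a labelled ligand from Adrenergic receptor alpha-1 (Homo sapiens) (on this read-out higher numbers stand for weaker inhibition and lower numbers for stronger inhibition), compound 1 gives 1.8 nM
compound 2, `Cn1c(=O)cnn(CCCCN2CCN(c3ccccc3)CC2)c1=O` — compound 2 gives 64 nM
compound 3, `Cn1c(=O)cnn(CCCCN2CCN(c3ccccc3S)CC2)c1=O` — compound 3 gives only a limit, > 10000 nM

The value of compound 3 is not a number but the limit of the assay, (the limit of > 10000 nM in this assay, at which 1 of the 3 values shown sits), so it stands at the weak end of everything measured here. Two steps lead into it. Adding a sulfanyl group on the aromatic carbon gave an at least 150-fold higher number from compound 2 to compound 3 (2.19 log units; beyond the scatter), and removing the methyl from the sulfur gave an at least 5500-fold higher number from compound 1 to compound 3 (3.74 log units; beyond the scatter), both large and both weakening. The third step, a 36-fold higher number from compound 1 to compound 2 (1.55 log units; beyond the scatter), also weakens, but far less.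

Compound 4, `Cn1c(=O)cnn(CCCCN2CCN(c3cccc(F)n3)CC2)c1=O`, takes the step (6-fluoropyridin-2-yl in place of 2-sulfanylphenyl on an amine nitrogen in a ring). For the measured compounds named here, this removes the sulfanyl-bearing ring that accompanied both large losses, and brings in a ring with no measured counterpart: nothing here tells what the pyridine nitrogen or the fluorine do.

Since the loss of the sulfanyl group reverses the step from compound 2 to compound 3, the number for compound 4 is expected to fall strongly, by about an at least 83-fold lower number from compound 3 to compound 4 (1.92 log units; beyond the scatter), and to land near compound 2. The estimate for compound 4 is 120 nM, with a range from 20 nM to 1500 nM.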

Compound 4, inhibition constant: > 10000 nM
Compound 4: only a limit was reported; the forecaster's own chance of this, stated with the estimate: 5%; at least 83-fold (1.92 log units) between middle value and limit.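

Removing the 2-sulfanylphenyl arm does not by itself bring binding back at this place on the ring nitrogen, as the 6-fluoropyridin-2-yl arm also sits far from the earlier measured compounds, with an at least 150-fold higher number from compound 2 to compound 4 (2.19 log units; beyond the scatter) and an at least 5500-fold higher number from compound 1 to compound 4 (3.74 log units; beyond the scatter). The poor result at this position is therefore not tied to the sulfanyl group alone, since a second arm with no sulfur ends in the same place, and the step between compound 3 and compound 4 cannot be read, as both results are limits and not numbers: the limit of > 10000 nM in this assay, at which 2 of the 4 values shown sit.

Among the arms shown, only the phenyl of compound 2 and the 2-(methylsulfanyl)phenyl of compound 1 give readable numbers, so this position accepts some aromatic arms and not others, with compound 3 and compound 4 going against any idea that a six-membered aromatic ring is enough.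

Going by these compounds, compound 4 brings in the pyridine nitrogen and the fluorine together, so it remains open which of the two goes with the loss. A plain pyridin-2-yl arm or a fluorophenyl arm would separate them, and either could show whether the loss needs both changes at once.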